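Series notes: from compound 1 toward compound 4

This account rests on a few compounds, and the source may have more. Where it says the series, first, only, none or still open, it means among the compounds named here.

Measured so far in a functional assay with Oryctolagus cuniculus as the target; a lower number here means a stronger inhibitor, a higher number a weaker inhibitor:
compound 1 `C/N=C(/NC)Nc1nc(-c2ccc(OC)cc2)c(-c2ccc(OC)cc2)s1` gives 970 nM;
compound 2 `COc1ccc(-c2nc(CN(C)C)sc2-c2ccc(OC)cc2)cc1` gives 96 nM;
compound 3 `COc1ccc(-c2nc(CNC(C)=O)sc2-c2ccc(OC)cc2)cc1` gives 15 nM.

Compound 1 stands at the highest number of the three; the nearest is a 10-fold lower number from compound 1 to compound 2 (1.00 log units; beyond the scatter) and the furthest a 65-fold lower number from compound 1 to compound 3 (1.81 log units; beyond the scatter). Compound 4 `COc1ccc(-c2nc(CNC(=O)N3CCOCC3)sc2-c2ccc(OC)cc2)cc1` differs from compound 1 by a group of 10 heavy atoms (6 carbon, 2 nitrogen, 2 oxygen; one six-membered non-aromatic ring with 2 hetero atoms) in place of a group of 6 heavy atoms (3 carbon, 3 nitrogen; no ring), on an aromatic carbon. Both measured steps away from compound 1 bear on this change: a 10-fold lower number from compound 1 to compound 2 (1.00 log units; beyond the scatter) (modest) and a 65-fold lower number from compound 1 to compound 3 (1.81 log units; beyond the scatter) (large). The entering group of compound 4 carries an amide, as compound 3 does, rather than the dimethylamino of compound 2, so a lower number beyond the scatter is expected, of a size nearer the step to compound 3. Compound 4 is expected at 30 nM, range 8 nM to 120 nM. Compound 4 is thus expected to show a 32-fold lower number from compound 1 to compound 4 (1.51 log units; beyond the scatter).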

Compound 4, half-maximal inhibitory concentration: 660 nM
Estimate against measurement, compound 4: 22-fold (1.34 log units) below, and the stated range ends below it.
By their numbers in this assay, from the lowest: compound 3; then compound 2; then compounds 4 and 1 (each within the scatter of the next).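

Keeping the carbonyl and changing only what it bears matters at this position: morpholin-4-yl in place of methyl on the carbonyl carbon gives a 44-fold higher number from compound 3 to compound 4 (1.64 log units; beyond the scatter) in this assay. The ((morpholin-4-yl)carbonyl)amino group also gives a 6.9-fold higher number from compound 2 to compound 4 (0.84 log units; beyond the scatter) against dimethylamino, and the change from the group of compound 1 gives only a 1.5-fold lower number from compound 1 to compound 4 (0.17 log units; within the scatter), so the low number of compound 3 does not extend to every carbonyl-bearing group here. No data at hand explain this loss.

Left open is whether a carbonyl bearing ethyl or a plain amino group stays near compound 3 or moves toward compound 4.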